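From an amide to a urea on a shared core

The source may report more compounds than this note shows. Statements on the series, on what has been measured and on what is new or still open speak of the compounds shown alone.

Compound 1 `COc1cc(-c2nn(-c3cccc(NC(=O)c4cccc(C(F)(F)F)c4)c3)cc2-c2ccncc2)ccc1Cl` and compound 2 `O=C(Nc1cccc(-n2cc(-c3ccncc3)c(-c3ccc(Cl)c(O)c3)n2)c1)Nc1cc(C(F)(F)F)cc(C(F)(F)F)c1` share a core and were both tested in a functional assay on KM12 cells (Homo sapiens) for inhibition, read by sulforhodamine B assay, with a stated time of 48 h; a higher number here means a weaker inhibitor, a lower number a stronger inhibitor. In this assay compound 1 gives 1660 nM, the higher of the two numbers, while compound 2 gives 510 nM, a gap that lies beyond the usual scatter. Among the measured compounds shown here, the two compounds differ in more than one place, so no single step between them can be separated out; only the two values themselves can be set side by side.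

Compound 3 `COc1cc(-c2nn(-c3cccc(NC(=O)Nc4ccc(Cl)c(C(F)(F)F)c4)c3)cc2-c2ccncc2)ccc1Cl` arises from compound 1 by one change: (4-chloro-3-(trifluoromethyl)phenyl)amino in place of 3-(trifluoromethyl)phenyl on a carbonyl carbon, a (4-chloro-3-(trifluoromethyl)phenyl)amino in place of 3-(trifluoromethyl)phenyl on a carbonyl carbon, which turns the amide into a urea. For the measured compounds named here, no measured pair shows exactly this step, so the expectation rests on compound 2, whose value of 510 nM comes from a urea on the shared core. The step expected from this change, a 2.6-fold lower number from compound 1 to compound 3 (0.41 log units; beyond the scatter), should point toward a stronger inhibitor, though it may end up within the scatter. The estimate for compound 3 in this assay is 650 nM, with a range from 220 nM to 1900 nM.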

Compound 3, half-maximal inhibitory concentration: 1060 nM
Estimate against measurement, compound 3: 1.6-fold (0.21 log units) below; low and high end bracket the measured number.
By their numbers in this assay, from the lowest: compound 2; then compounds 3 and 1 (each within the scatter of the next).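

Among the compounds shown here, this is the first step that can be read at a single place, and it gives a 1.6-fold lower number from compound 1 to compound 3 (0.19 log units; within the scatter) in this assay. Swapping 3-(trifluoromethyl)phenyl for (4-chloro-3-(trifluoromethyl)phenyl)amino on the carbonyl carbon turns the amide into a urea and adds a hydrogen-bond donor and a chlorine, yet on the core of compound 1 this exchange does not produce a difference that can be told apart from ordinary repeat-to-repeat variation. No accompanying measurement speaks to the reason for this outcome.

Going by these compounds, the new nitrogen and the new chlorine enter together, so their separate contributions stay unknown, and a urea ending in an unsubstituted phenyl ring or one carrying fluorine in place of chlorine would be needed to pull them apart. On these data alone, it also remains open how this position would respond to a different link to the carbonyl carbon, such as an oxygen atom in a carbamate, or to a saturated ring such as morpholine in place of the aromatic ring.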